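Swapping Bromo for Trifluoromethyl: Compound 3 to Compound 4

This account rests on a few compounds, and the source may have more. Where it says the series, first, only, none or still open, it means among the compounds named here.

Measured so far in an assay on HEK293F cells for inhibition of cholesterol 24-hydroxylase (Homo sapiens), read by trypan blue exclusion, with stated times of 15 min and 5 h; a higher number here means a weaker inhibitor, a lower number a stronger inhibitor:
- compound 1 `CN(C)C(=O)C1CCN(c2cnccc2-n2cccn2)CC1` gives 48 nM
- compound 2 `Cc1cnn(-c2ccncc2N2CCC(C(=O)N(C)C)CC2)c1` gives 8.5 nM
- compound 3 `CN(C)C(=O)C1CCN(c2cnccc2-n2cc(Br)cn2)CC1` gives 9.5 nM

Compound 3 stands second highest of the three numbers in this assay: its nearest neighbour is compound 2, from which it differs within the scatter (a 1.1-fold higher number from compound 2 to compound 3 (0.05 log units; within the scatter)), and its furthest is compound 1, from which it is set apart (a 5.1-fold lower number from compound 1 to compound 3 (0.70 log units; beyond the scatter)). Compound 4 `CN(C)C(=O)C1CCN(c2cnccc2-n2cc(C(F)(F)F)cn2)CC1` is not yet measured. It differs from compound 3 in one place: trifluoromethyl in place of bromo on an aromatic carbon.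

Among the measured compounds shown here, two measured steps bear on this change. Placing a group on the bare aromatic carbon of compound 1 helped in both cases (a 5.6-fold lower number from compound 1 to compound 2 (0.75 log units; beyond the scatter) and a 5.1-fold lower number from compound 1 to compound 3 (0.70 log units; beyond the scatter)), and exchanging one such group for another made no difference beyond the scatter (a 1.1-fold higher number from compound 2 to compound 3 (0.05 log units; within the scatter)). A trifluoromethyl at the same place is therefore expected to behave like methyl and bromo did, giving for compound 4 a step of about a 1.1-fold higher number from compound 3 to compound 4 (0.02 log units; within the scatter), within the scatter. Compound 4 is estimated at 10 nM, between 4 nM and 25 nM.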

Compound 4, half-maximal inhibitory concentration: 65 nM
Estimate against measurement, compound 4: 6.5-fold (0.81 log units) below, outside the stated range (above it).
By their numbers in this assay, from the lowest: compounds 2 and 3 (each within the scatter of the next); then compounds 1 and 4 (each within the scatter of the next).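

In this assay, this aromatic carbon does not treat all substituents alike: a 6.8-fold higher number from compound 3 to compound 4 (0.84 log units; beyond the scatter) and a 7.6-fold higher number from compound 2 to compound 4 (0.88 log units; beyond the scatter) show that the match between methyl and bromo does not extend to trifluoromethyl. The benefit of substitution at this position is also not general, since trifluoromethyl in place of hydrogen gives a 1.4-fold higher number from compound 1 to compound 4 (0.13 log units; within the scatter), leaving compound 4 within the scatter of the unsubstituted compound. No measurement available here accounts for this loss.

From the compounds shown here alone, it remains open whether a chloro, an ethyl, a methoxy or a nitrile at the same carbon would group with methyl and bromo or with trifluoromethyl. Going by these compounds, it is also open whether the step from bromo to trifluoromethyl would keep its size if the amide of the shared core were replaced.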